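Pyridin-2-yl Replaces a Pyrazole on a Shared Triazine Core

The source may hold more compounds than are shown below. What is called first, only, known or untested is meant among the compounds shown, and "the series" means these compounds.

Measured so far:
Compound 1, `NS(=O)(=O)c1ccc(Nc2nc(N/N=C/c3ccc(C(F)(F)F)cc3)nc(Nc3ccccc3)n2)cc1`, gives 3300 nM in a functional assay on SW-620 cells (Homo sapiens) for inhibition, read by sulforhodamine B assay, with a stated time of 48 h; on this read-out higher numbers stand for weaker inhibition of growth and lower numbers for stronger inhibition of growth.
Compound 2, `Cc1nn(-c2ccccc2)cc1/C=N/Nc1nc(Nc2ccccc2)nc(Nc2ccc(S(N)(=O)=O)cc2)n1`, gives 3380 nM in this assay.

Compound 2 holds the higher of these two numbers, but only by a hair: the step of a 1.0-fold higher number from compound 1 to compound 2 (0.01 log units; within the scatter) lies within the scatter, so the two compounds stand level in this assay and neither can be called weaker or stronger.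

Compound 3, `NS(=O)(=O)c1ccc(Nc2nc(N/N=C/c3ccccn3)nc(Nc3ccccc3)n2)cc1`, differs from compound 2 by pyridin-2-yl in place of 3-methyl-1-phenyl-1H-pyrazol-4-yl on a carbon with a double bond to nitrogen. Within the data shown here, the one measured step that touches this same carbon is a 1.0-fold higher number from compound 1 to compound 2 (0.01 log units; within the scatter), where one aromatic group gave way to a quite different one and the number did not move beyond the scatter. On that basis the step of a 1.0-fold higher number from compound 2 to compound 3 (0.02 log units; within the scatter) is expected to be small in either direction, none beyond the scatter. Compound 3 is therefore estimated at 3500 nM, with a range from 1200 nM to 10000 nM.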

Compound 3, concentration for 50% growth inhibition: 710 nM
Beside the measured number, compound 3's estimate is 4.9-fold (0.69 log units) above it; the whole stated range lies above it.
By their numbers in this assay, from the lowest: compound 3; then compounds 1 and 2 (each within the scatter of the next).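

The earlier pair hinted that this carbon with a double bond to nitrogen might accept any aromatic group without change, but in this assay pyridin-2-yl brings a 4.8-fold lower number from compound 2 to compound 3 (0.68 log units; beyond the scatter) and a 4.6-fold lower number from compound 1 to compound 3 (0.67 log units; beyond the scatter). So the group here does matter: 3-methyl-1-phenyl-1H-pyrazol-4-yl and 4-(trifluoromethyl)phenyl stand level, while pyridin-2-yl, the smaller group with a single ring, stands apart from both on the side of stronger inhibition of growth. Nothing measured here explains this difference.

The compounds shown leave open whether the ring nitrogen or simply the smaller group goes with the lower number. A plain phenyl, pyridin-3-yl or pyridin-4-yl on this same carbon would help to separate those two readings.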